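Working notes: from compound 1 to compound 4

The compounds below may be only part of what the source reports. "The series", "measured", "known", "first", "only" and "open" are said of these compounds alone.

Measured in a functional assay on IMR-32 cells (Homo sapiens) for cytotoxicity, read by sulforhodamine B assay, with a stated time of 48 h (on this read-out lower numbers stand for stronger inhibition and higher numbers for weaker inhibition), as follows
- compound 1 `C=CCOc1ccc(F)cc1C(=O)c1cccnc1` gives 91000 nM here
- compound 2 `O=C(c1cccnc1)c1cc(F)ccc1O` gives 6210 nM here
- compound 3 `O=C(c1cccnc1)c1cccc(Cl)c1O` gives 26000 nM here

Compound 1 stands highest of the three at 91000 nM on this read-out, with compound 3 nearest at 26000 nM and compound 2 furthest at 6210 nM in the same direction. Compound 4 `C=CCOc1ccc(C)cc1C(=O)c1cccnc1` remains unmeasured and differs from compound 1 by methyl in place of fluoro on an aromatic carbon, para to an allyloxy group methyl in place of fluoro on an aromatic carbon with the rest unchanged. Among the compounds with values here, the one measured single-place step is a 15-fold lower number from compound 1 to compound 2 (1.17 log units; beyond the scatter) and it is large, yet it removes the allyl on the oxygen and leaves the fluoro in place. Within the data shown here, no measured step touches the carbon that changes here. Compound 4 keeps the allyloxy group, so no step beyond the scatter is expected in this assay and neither direction is favoured. The expected change is a 1.1-fold lower number from compound 1 to compound 4 (0.03 log units; within the scatter) by this estimate. For compound 4 the estimated value is 85000 nM with an expected range from 40000 nM to 180000 nM on this read-out.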

Compound 4, half-maximal inhibitory concentration: 87000 nM
The estimate for compound 4 lay 1.0-fold (0.01 log units) below the measured number; the measured number falls inside the stated range.
By their numbers in this assay, from the lowest: compound 2; then compound 3; then compounds 4 and 1 (each within the scatter of the next).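

In this assay, methyl in place of fluoro on an aromatic carbon, para to an allyloxy group, gives a 1.0-fold lower number from compound 1 to compound 4 (0.02 log units; within the scatter), so with the allyloxy group kept, the two groups are not told apart at this position. Within the data shown here, this is the first reading at this carbon, since the earlier step, a 15-fold lower number from compound 1 to compound 2 (1.17 log units; beyond the scatter), concerned the allyl on the oxygen and left the fluoro in place. Nothing available gives a reason for this result.

Other groups on this carbon, such as an amine, a carboxylic acid or a longer chain, remain open, so fluoro and methyl alone do not show how far this tolerance extends. Also open, going by these compounds, is whether methyl in place of fluoro reads the same with hydrogen in place of allyl on the oxygen, as in compound 2.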